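The source may hold more compounds than are shown below. What is called first, only, known or untested is meant among the compounds shown, and "the series" means these compounds.

Working notes on the series. Compound 2 `O=C(Nc1cccc(-c2oc3cc(-c4ccc(F)cc4)ccc3c(=O)c2O)c1)c1cccc(F)c1` gives 15800 nM in a functional assay on GTL 16 cells for antiproliferative activity against GTL 16 cell line (Homo sapiens), read by CCK-8 assay, with a stated time of 72 h; a higher number here means a weaker inhibitor, a lower number a stronger inhibitor. Compound 1 `O=C(Nc1cccc(-c2oc3cc(-c4ccc(F)cc4)ccc3c(=O)c2O)c1)c1ccc(Br)cc1` gives 25400 nM in this assay, and the step of a 1.6-fold lower number from compound 1 to compound 2 (0.21 log units; within the scatter) lies within the scatter, so compound 2 stands alongside compound 1 rather than apart from it. Compound 3 `Cc1cc(C(=O)Nc2cccc(-c3oc4cc(-c5ccc(F)cc5)ccc4c(=O)c3O)c2)ccc1F` differs from compound 2 by 4-fluoro-3-methylphenyl in place of 3-fluorophenyl on a carbonyl carbon. Within the data shown here, the only measured step, a 1.6-fold lower number from compound 1 to compound 2 (0.21 log units; within the scatter), also exchanges one aryl group for another on the same carbonyl carbon and stays within the scatter, and the present change keeps the 3-fluorophenyl pattern while adding a methyl. On this basis the step expected in this assay is a 1.1-fold lower number from compound 2 to compound 3 (0.02 log units; within the scatter), with no movement beyond the scatter in either direction. Compound 3 is expected to give 15000 nM in this assay, estimated to fall between 6000 nM and 38000 nM.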

Compound 3, half-maximal inhibitory concentration: 12100 nM
Compound 3: the middle estimate sits 1.2-fold (0.09 log units) above what was measured, within the range that was stated.
By their numbers in this assay, from the lowest: compounds 3, 2 and 1 (each within the scatter of the next, the first and the last beyond it).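

In this assay, 4-fluoro-3-methylphenyl in place of 3-fluorophenyl on the carbonyl carbon gives a 1.3-fold lower number from compound 2 to compound 3 (0.12 log units; within the scatter) and so leaves compound 3 alongside compound 2. Among these compounds, the same group in place of 4-bromophenyl gives a 2.1-fold lower number from compound 1 to compound 3 (0.32 log units; beyond the scatter) and is the first step at this position to pass the scatter, although compound 2 remains within the scatter of both other compounds. Nothing available bears on the reason for either step.

Going by these compounds, all three compounds carry a substituted phenyl group on this carbonyl carbon, so the response to an amine, a carboxylic acid or a longer alkyl chain at this place remains open. The effect of changes elsewhere on the shared core also remains open, as the compounds shown differ only at this one place.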